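The source may hold more compounds than are shown below. What is called first, only, known or untested is meant among the compounds shown, and "the series" means these compounds.

The measured compounds:
Compound 1, `Brc1ccc(-n2cc(CSc3nc4ccccc4s3)nn2)cc1`, gives 59.2% in a functional assay on the whole organism (strain Albino Wistar) for inhibition, with Rattus norvegicus as the target, read by paw edema, with stated times of 1 h and 5 h, at a dose of 10 mg/kg by the oral route; a higher number here means more inhibition at the dose given (going by the name of the read-out), a lower number less inhibition.
Compound 2, `c1ccc(-n2cc(CSc3nc4ccccc4s3)nn2)cc1`, gives 32.1% in this assay.

Compound 2 stands at the lower of the two numbers in this assay. Among the measured compounds shown here, its nearest neighbour is compound 1, and the single measured step, a number 27.1 percentage points lower from compound 1 to compound 2 (beyond the scatter), sets the gap between them, a gap beyond the scatter and modest in size. Compound 3, `CC1(C)OCC(Cn2cc(CSc3nc4ccccc4s3)nn2)O1`, differs from compound 2 by (2,2-dimethyl-1,3-dioxolan-4-yl)methyl in place of phenyl on an aromatic nitrogen. For the measured compounds named here, the one measured step concerns a bromo on the phenyl ring, and that very ring now leaves, so the step bears on the new change only loosely: it shows that an alteration at this position moves the read-out in this assay beyond the scatter, but it does not say in which direction a wholly new group would move it. In the absence of a closer precedent the step is expected to stay near zero, as a number 2.9 percentage points higher from compound 2 to compound 3 (within the scatter), with wide uncertainty. Compound 3 is therefore estimated at 35%, within a range of 12% to 60%.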

Compound 3, a percentage reported as inhibition, in the whole organism at one dose (the size of the read-out at that dose, not a potency): 49.1%
Beside the measured number, compound 3's estimate is 14.1 percentage points below it; the measured number falls inside the stated range.
By their numbers in this assay, from the lowest: compound 2; then compound 3; then compound 1.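

In this assay, the nitrogen that carried the phenyl group also accepts a group with no aromatic ring: (2,2-dimethyl-1,3-dioxolan-4-yl)methyl gives a number 17 percentage points higher from compound 2 to compound 3 (beyond the scatter) and so improves on the unsubstituted phenyl, which the bromo step alone could not show. The same group does not match the 4-bromophenyl group, with a number 10.1 percentage points lower from compound 1 to compound 3 (beyond the scatter) in this comparison, so among these three compounds the order runs from compound 2 through compound 3 to compound 1, and the aromatic ring is neither required for the read-out nor lost without cost. Nothing measured here explains why the new group lands between the two aryl groups.

The change swaps the ring type, adds two hydrogen-bond acceptors and adds heavy atoms all at once, so these three compounds cannot say which of those differences goes with the rise from compound 2 to compound 3. As far as these compounds go, how a benzyl group, a plain butyl chain or a morpholine-bearing chain on this nitrogen would read stays open, as does whether chloro or methoxy in place of the bromo would hold the level of compound 1.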